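The compounds below may be only part of what the source reports. "The series", "measured", "known", "first", "only" and "open" are said of these compounds alone.

Working notes on the series. Compound 3 `CC(C)(N)CNC(=O)c1c(Nc2ccc(I)cc2F)sc2c1CC(C)(C)CNC2=O` gives 79 nM in a functional assay on HT-29 cells (Homo sapiens) for antiproliferative activity; on this read-out lower numbers stand for stronger inhibition and higher numbers for weaker inhibition. Its number lies between those of compound 1 `CC1(C)CNC(=O)c2sc(Nc3ccc(I)cc3F)c(C(=O)N[C@@H]3CCNC3)c2C1`, which gives 54 nM, and compound 2 `CC1(C)CNC(=O)c2sc(Nc3ccc(I)cc3F)c(C(=O)NC[C@H]3CCCN3)c2C1`, which gives 120 nM; both steps to compound 3 are within the scatter, a 1.5-fold higher number from compound 1 to compound 3 (0.17 log units; within the scatter) and a 1.5-fold lower number from compound 2 to compound 3 (0.18 log units; within the scatter), so the three amine-bearing amide substituents are not separated by these numbers. Among the compounds with values here, the only step beyond the scatter among them is a 2.2-fold higher number from compound 1 to compound 2 (0.35 log units; beyond the scatter), and it is modest.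

Compound 4 `CC1(C)CNC(=O)c2sc(Nc3ccc(I)cc3F)c(C(=O)NOC[C@H](O)CO)c2C1` has not been measured. The change from compound 3 is 2,3-dihydroxypropoxy in place of 2-amino-2-methylpropyl on an amide-type nitrogen. Within the data shown here, every measured step so far exchanges one amine-carrying group for another; none removes the amine and none introduces an oxygen-linked group on the amide-type nitrogen, so no measured step bears directly on this change. The steps that do exist were small, which gives no ground to expect a large shift, but the change here is of a different kind, and the direction is open.

On that basis a weak-to-modest increase in number is expected, a 2.0-fold higher number from compound 3 to compound 4 (0.31 log units; beyond the scatter), with compound 4 estimated at 160 nM, range 50 nM to 600 nM.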

Compound 4, half-maximal inhibitory concentration: 1580 nM
Compound 4: the middle estimate sits 9.9-fold (0.99 log units) below what was measured; measured number above the stated range.
By their numbers in this assay, from the lowest: compounds 1, 3 and 2 (each within the scatter of the next, the first and the last beyond it); then compound 4.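

The position on the amide-type nitrogen proves sensitive to the kind of group it carries: the amine-bearing substituents differ by at most a modest step, whereas 2,3-dihydroxypropoxy brings a 20-fold higher number from compound 3 to compound 4 (1.30 log units; beyond the scatter), a 13-fold higher number from compound 2 to compound 4 (1.12 log units; beyond the scatter) and a 29-fold higher number from compound 1 to compound 4 (1.47 log units; beyond the scatter). All three steps are large and run in the same direction, so compound 4 stands apart from every amine-bearing compound in the series, and the choice among those amines matters far less here than the change away from them. No measurement on hand accounts for this loss of inhibition.

The change removes the amine, adds the oxygen link to the amide-type nitrogen and brings in the hydroxyl groups all at once, so the compounds shown cannot assign the large step to any one of these. A 2-aminoethoxy group, which keeps an amine on the oxygen link, and a 2,3-dihydroxypropyl group, which keeps the diol on a carbon link, would separate these contributions.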